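This account rests on a few compounds, and the source may have more. Where it says the series, first, only, none or still open, it means among the compounds named here.

Three compounds have been measured so far:

Compound 1, `Cc1cccc(S(=O)(=O)Nc2ccc(-c3nc4ccccc4o3)cc2)c1`: in an assay on isolated protein for inhibition of malate dehydrogenase, mitochondrial (Sus scrofa), with stated times of 45 min and 30 min (on this read-out lower numbers stand for stronger inhibition and higher numbers for weaker inhibition), compound 1 gives > 63000 nM, a limit of the assay and not a number.
Compound 2, `O=S(=O)(Nc1ccc(-c2nc3ccccc3o2)cc1)c1cccc(C(F)(F)F)c1`: in this assay compound 2 gives > 63000 nM, again a limit.
Compound 3, `O=S(=O)(Nc1ccc2oc(-c3ccccc3)nc2c1)c1cccc(O)c1`: in this assay compound 3 gives > 63000 nM, once more a limit.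

Compound 1 therefore stands at the limit of > 63000 nM in this assay, at which 3 of the 3 values shown sit. For it, as for the two others, only a limit is known, no number.

The compound still to be measured is compound 4, `O=S(=O)(Nc1ccc(-c2nc3ccccc3o2)cc1)c1ccc(O)cc1`. It differs from compound 1 in one place: 4-hydroxyphenyl in place of 3-methylphenyl on a sulfonyl sulfur. Among the measured compounds shown here, only one measured step joins two compounds that differ in a single place, a step that the two limits leave unreadable from compound 1 to compound 2. For the measured compounds named here, both of its ends are limits, so its size cannot be read, and it concerns a different change than the one leading to compound 4. With every value shown sitting at the limit, the data give no footing for a step in either direction beyond the scatter, and no footing for a number at all.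

The expectation for compound 4 is accordingly that it too gives only a limit in this assay, estimated at about 63000 nM, with a range from 15000 nM to 250000 nM. The expected step, a number no higher from compound 1 to compound 4 (the limit leaves the size open), is none beyond the scatter.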

Compound 4, half-maximal inhibitory concentration: > 63000 nM
Compound 4: no number, only a limit (the forecaster's own chance of this, stated with the estimate: 80%); the middle value sits exactly at the limit.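

In this assay compound 4 gives > 63000 nM, a limit of the assay and not a number. Compound 1 also has only a limit, so the step from compound 1 to compound 4 cannot be read. The compounds shown leave open how strongly, if at all, any of them inhibits this enzyme, and which change would alter that.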